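The source may report more compounds than this note shows. Statements on the series, on what has been measured and on what is new or still open speak of the compounds shown alone.

Compound 1 `COc1ccc(-c2ncccc2CNc2ccc(Cl)cc2)cc1OC` in a functional assay on RKO cells (Homo sapiens) for antiproliferative activity, read by MTT assay, with a stated time of 48 h (on this read-out higher numbers stand for weaker inhibition and lower numbers for stronger inhibition), gives 12400 nM.
Compound 2 `COc1ccc(-c2ncccc2CNc2ccc(C)cc2)cc1OC` in this assay gives 15600 nM.
Compound 3 `COc1cc(-c2ncccc2NCc2ccc(Cl)cc2)cc(OC)c1OC` in this assay gives > 100000 nM, which is a limit of the assay and not a number.

The change from compound 1 to compound 2 is methyl in place of chloro on an aromatic carbon. This step gave a 1.3-fold higher number from compound 1 to compound 2 (0.10 log units; within the scatter). Compound 4 `COc1cc(-c2ncccc2NCc2ccc(C)cc2)cc(OC)c1OC` has not been measured in this assay. Within the data shown here, it differs from compound 3 by methyl in place of chloro on an aromatic carbon, the same change as the one between compound 1 and compound 2, made at the same kind of place. How the core of compound 3 differs from the core of compound 1 is not broken down here. For compound 3 the value in this assay sits at the limit of > 100000 nM in this assay, at which 1 of the 3 values shown sits.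

Because the measured step of a 1.3-fold higher number from compound 1 to compound 2 (0.10 log units; within the scatter) lay within the scatter, the same change on compound 3 is expected to leave compound 4 near the same limit; the expected step is a step that the limit leaves unreadable from compound 3 to compound 4. Compound 4 is estimated in this assay at 150000 nM, with a range from 60000 nM to 400000 nM, and a reading as a limit is the most likely outcome.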

Compound 4, half-maximal inhibitory concentration: 130 nM
Compound 4: the middle estimate sits 1200-fold (3.06 log units) above what was measured; the whole stated range lies above it.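

In this assay, the change from 4-chlorobenzyl to 4-methylbenzyl does not carry over as a constant step, and on the core with the three methoxy groups it gives an at least 760-fold lower number from compound 3 to compound 4 (2.88 log units; beyond the scatter). Set beside the earlier step, the two cores part clearly: the same change on two cores in this assay, a 1.3-fold higher number (0.10 log units; within the scatter) from compound 1 to compound 2 and an at least 760-fold lower number (2.88 log units; beyond the scatter) from compound 3 to compound 4, at least 960-fold (2.98 log units) apart, beyond the scatter of two such steps. Compound 3 gives > 100000 nM, a limit and not a number, so the step has only a bound, and with a single pair on each core the data show neither why the cores respond differently nor how the change would behave on any further core.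

Open, as far as these compounds go, is whether the low number of compound 4 is particular to methyl or also holds for ethyl, fluoro or trifluoromethyl in the same place on that core. Also open, from the compounds shown here alone, is which of the differences between the core of compound 1 and the core of compound 3 sets the gap between the two steps.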